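A halogen swap on the benzyl arm

The compounds below may be only part of what the source reports. "The series", "measured", "known", "first", "only" and "open" are said of these compounds alone.

Measured compounds:
compound 1, `COC(=O)c1ccc(NCc2cncn2Cc2ccccc2-c2ccccc2)cc1-c1ccccc1`, in a toxicity assay on NIH3T3 cells (Mus musculus) for cytotoxicity, read by resazurin assay (a higher number here means that more compound is needed for the effect, a lower number that less compound is needed), compound 1 gives "not determined" (no result reported)
compound 2, `COC(=O)c1ccc(NCc2cncn2Cc2cccc(F)c2)cc1-c1ccccc1`, in this assay compound 2 gives > 1000 nM

Compound 1 carries no result in this assay. For compound 2, the value > 1000 nM in this assay is a limit of the assay and not a number, which is where compound 2 stands, as the one entry sitting at the limit of > 1000 nM in this assay, at which 1 of the 2 values shown sits. For the measured compounds named here, with one limit and one missing result, no step between measured compounds can be drawn.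

Compound 3, `COC(=O)c1ccc(NCc2cncn2Cc2ccc(Br)cc2)cc1-c1ccccc1`, differs from compound 2 in one place: 4-bromophenyl in place of 3-fluorophenyl on a saturated chain carbon bound to an aromatic nitrogen. Since compound 2 shows only the limit > 1000 nM, compound 3 is expected to stay at or beyond that limit too. The step expected in this assay is a step that the limit leaves unreadable from compound 2 to compound 3, most likely none beyond the scatter. Compound 3 is estimated at 3000 nM, with a range from 1000 nM to 10000 nM.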

Compound 3, half-maximal effective concentration: > 10000 nM
Compound 3: only a limit was reported; the forecaster's own chance of this, stated with the estimate: 85%; middle value at least 3.3-fold (0.52 log units) from the limit.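

In this assay, compound 2 and compound 3 each carry only a limit, and no step can be read between them. The compounds shown leave open where either one's actual value lies, and whether 4-bromophenyl in place of 3-fluorophenyl shifts the read-out at all.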